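Phenyl in place of benzofuranyl on the nucleoside core

This account rests on a few compounds, and the source may have more. Where it says the series, first, only, none or still open, it means among the compounds named here.

This account follows three nucleosides sharing a core and one more built on it. Compound 1 `COc1ncnc2c1c(I)cn2[C@@H]1O[C@H](CO)[C@@H](O)[C@H]1O` was tested in a functional assay on K562 cells (Homo sapiens), read by MTT assay, with a stated time of 72 h (a lower number here means a stronger inhibitor, a higher number a weaker inhibitor), and gave 14800 nM. Compound 2 `O=c1[nH]cnc2c1c(-c1cc3ccccc3o1)cn2[C@@H]1O[C@H](CO)[C@@H](O)[C@H]1O` reached only the limit of > 20000 nM in this assay, a limit rather than a number. Compound 3 `Nc1nc2c(c(-c3ccco3)cn2[C@@H]2O[C@H](CO)[C@@H](O)[C@H]2O)c(=O)[nH]1` likewise gave only the limit of > 20000 nM in this assay. Compound 2 therefore stands at the weak end of what was measured, and this is noted in the limit of > 20000 nM in this assay, at which 2 of the 3 values shown sit. No pair of these compounds differs in a single place, so no step between measured values can be drawn.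

Compound 4 `O=c1[nH]cnc2c1c(-c1ccccc1)cn2[C@@H]1O[C@H](CO)[C@@H](O)[C@H]1O` differs from compound 2 in one place: phenyl in place of 1-benzofuran-2-yl on an aromatic carbon. Since compound 2 gave only a limit, the step is expected to be small or none beyond the scatter, and the value of compound 4 is expected to sit near the limit again. The step this estimate means, a step that the limit leaves unreadable from compound 2 to compound 4, is expected to lie within the usual scatter. Compound 4 is thus estimated at 25000 nM, with a range from 8000 nM to 80000 nM.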

Compound 4, half-maximal inhibitory concentration: > 20000 nM
Compound 4 was reported as a limit; the forecaster's own chance of this, stated with the estimate: 65%; the middle value is on the limit's open side.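

Among these compounds, compound 2 and compound 4 both stand only as limits in this assay, so no step between them can be read: the limit of > 20000 nM in this assay, at which 3 of the 4 values shown sit.

The compounds shown leave open whether phenyl and 1-benzofuran-2-yl on the shared core differ at all in this assay.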